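Carbonyl-for-sulfonyl swap on the shared core

The compounds below may be only part of what the source reports. "The series", "measured", "known", "first", "only" and "open" are said of these compounds alone.

The series shares the core of compound 2 `CC(C)S(=O)(=O)N1CCc2nc(C#Cc3ccccc3)sc2C1`. Among the measured compounds shown here, in an assay on HEK293 cells for negative allosteric modulation of metabotropic glutamate receptor 5 (Homo sapiens), read by FLIPR, with a stated time of 1 h (on this read-out higher numbers stand for weaker inhibition and lower numbers for stronger inhibition), compound 2 gives 11 nM, the only number measured. Compound 1 `COC1CC(C(=O)N2CCc3nc(C#Cc4ccccc4)sc3C2)C1` in this assay gives > 10000 nM, which is a limit of the assay and not a number. For the measured compounds named here, the one measured step runs an at least 900-fold lower number from compound 1 to compound 2 (2.95 log units; beyond the scatter). Compound 3 `O=C(N1CCCCC1)N1CCc2nc(C#Cc3ccccc3)sc2C1` reverses that direction of change: (piperidin-1-yl)carbonyl in place of isopropylsulfonyl on an amine nitrogen in a ring. Going by the values given here, the only step that bears on it is that from compound 1 to compound 2, where a carbonyl-linked group gave way to a sulfonyl group and the number fell beyond the scatter; compound 3 returns to a carbonyl-linked group, and a loss in this assay is therefore expected, perhaps large, although the piperidine ring differs from the methoxycyclobutyl ring of compound 1. For compound 3 the expected step is a 140-fold higher number from compound 2 to compound 3 (2.13 log units; beyond the scatter). Compound 3 is estimated at 1500 nM, within 150 nM to 10000 nM, with a real chance that only the limit of > 10000 nM in this assay, at which 1 of the 2 values shown sits, is reached.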

Compound 3, half-maximal inhibitory concentration: > 10000 nM
Compound 3: a limit, no number; the forecaster's own chance of this, stated with the estimate: 30%; middle value at least 6.6-fold (0.82 log units) from the limit.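

With a second carbonyl-linked group on the amine nitrogen in the ring, the loss is no longer confined to the (3-methoxycyclobutyl)carbonyl group: in this assay the change to (piperidin-1-yl)carbonyl gives an at least 900-fold higher number from compound 2 to compound 3 (2.95 log units; beyond the scatter). Among these three compounds, only compound 2, with isopropylsulfonyl, gives a number. Compound 3 gives a limit and not a number, as does compound 1: the limit of > 10000 nM in this assay, at which 2 of the 3 values shown sit.

The step between compound 1 and compound 3 cannot be read, so the piperidin-1-yl and 3-methoxycyclobutyl groups on the carbonyl carbon cannot be ordered. Still open, on these data alone, is whether the linking group or the group it carries decides the outcome, since isopropylcarbonyl would keep the isopropyl group while replacing the sulfonyl, and piperidin-1-ylsulfonyl would keep the sulfonyl while carrying the piperidine ring.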